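Swapping Phenyl for Methylthiazole: Expected Cytotoxicity

The source may report more compounds than this note shows. Statements on the series, on what has been measured and on what is new or still open speak of the compounds shown alone.

Measured compounds:
compound 1, `O=C1CC(c2ccccc2)CN1c1cnn2c1CN(C(=O)Nc1cc(F)c(F)c(F)c1)C(C1CC1)C2`: 12800 nM
compound 2, `C[C@H]1Cn2ncc(N3CC(c4ccccc4)CC3=O)c2CN1C(=O)NCc1cc(F)c(F)c(F)c1`: > 2000 nM
compound 3, `O=C1CC(c2ccccc2)CN1c1cnn2c1CN(C(=O)Nc1cc(F)c(F)c(F)c1)C(Cc1ccccc1)C2`: > 2000 nM

For the measured compounds named here, in a toxicity assay on HepG2 2.2.15 cells (Homo sapiens) for cytotoxicity, read by CellTiter-Glo (on this read-out lower numbers stand for higher toxicity in this test and higher numbers for lower toxicity in this test), compound 1 gives 12800 nM, the only full number among the three measured compounds. For compound 2 this assay reports only a limit, > 2000 nM. For compound 3 the result is likewise a limit, > 2000 nM. Hence the step that the limit leaves unreadable from compound 1 to compound 3 cannot be read, as the limit of > 2000 nM in this assay, at which 2 of the 3 values shown sit, shows. Compound 4, `Cc1cnc(C2CC(=O)N(c3cnn4c3CN(C(=O)Nc3cc(F)c(F)c(F)c3)C(C3CC3)C4)C2)s1`, differs from compound 1 by 5-methyl-1,3-thiazol-2-yl in place of phenyl on a saturated ring carbon. Going by the values given here, no measured step touches this change, so nothing points to a shift in either direction beyond the usual scatter. The expected step is therefore a 1.1-fold lower number from compound 1 to compound 4 (0.03 log units; within the scatter). Compound 4 is estimated to give 12000 nM in this assay, with a likely range from 4000 nM to 40000 nM.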

Compound 4, half-maximal cytotoxic concentration: 96200 nM
Estimate against measurement, compound 4: 8.0-fold (0.90 log units) below; the whole stated range lies below it.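

This position matters in this assay: 5-methyl-1,3-thiazol-2-yl in place of phenyl gives a 7.5-fold higher number from compound 1 to compound 4 (0.88 log units; beyond the scatter). Here a higher number stands for lower toxicity in this test, so the group on this saturated ring carbon can shift the read-out. Compounds 1, 2 and 3 all carry phenyl here and could not show this.

As far as these compounds go, whether the step follows the ring's hetero atoms or its methyl stays open, as does the outcome with a pyridyl ring or an amine here. Steps involving compound 2 or compound 3 cannot be read because their values are limits: the limit of > 2000 nM in this assay, at which 2 of the 4 values shown sit.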